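The compounds below may be only part of what the source reports. "The series", "measured", "known", "first", "only" and "open" are said of these compounds alone.

Measured so far:
- compound 1, `CS/C(=N\C(=O)c1ccno1)NC(=O)c1ccno1`: in a functional assay on K562 cells (Homo sapiens) for cytotoxicity, read by MTT assay, with a stated time of 72 h (a higher number here means that more compound is tolerated, a lower number that less compound is tolerated), compound 1 gives > 100000 nM, which is a limit of the assay.
- compound 2, `C[Se]/C(=N\C(=O)c1ccco1)NC(=O)c1ccco1`: in this assay compound 2 gives > 100000 nM, again a limit of the assay.

Compound 2 thus stands at the limit of > 100000 nM in this assay, at which 2 of the 2 values shown sit, and no number for it is known. Compound 1 and compound 2 differ in more than one place, so their two values show only that each sits at that limit. Compound 3, `CS/C(=N\C(=O)c1ccco1)NC(=O)c1ccco1`, is reached from compound 2 by a group of 2 heavy atoms (1 carbon, 1 sulfur; no ring) in place of a group of 2 heavy atoms (1 carbon, 1 selenium; no ring), on a carbon with a double bond to nitrogen; in words, a group of 2 heavy atoms (1 carbon, 1 sulfur; no ring) in place of a group of 2 heavy atoms (1 carbon, 1 selenium; no ring), on a carbon with a double bond to nitrogen. With compound 1 also at the limit, the expected step in this assay is none beyond the scatter. Compound 3 is expected to give 150000 nM, in the range 50000 nM to 500000 nM. The expected step that the limit leaves unreadable from compound 2 to compound 3 is essentially flat, most likely another limit.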

Compound 3, concentration lethal to 50% of the cells: > 100000 nM
Compound 3 was reported as a limit (the forecaster's own chance of this, stated with the estimate: 85%); the middle value lies beyond the limit too.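

No step from compound 2 to compound 3 can be read in this assay, since both values are limits of the assay: the limit of > 100000 nM in this assay, at which 3 of the 3 values shown sit.

The compounds shown leave open what number any of them would give in this assay, and so what methylsulfanyl in place of the selenium group changes.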